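The source may report more compounds than this note shows. Statements on the series, on what has been measured and on what is new or still open speak of the compounds shown alone.

Compound 1 `COc1cc(-c2nc(SCc3cn(CC(=O)NC(=O)Nc4ccccn4)nn3)nc(Nc3ccc(C)cc3)c2C#N)cc(OC)c1OC` gives 21300 nM in a functional assay on ECa-109 cells (Homo sapiens) for inhibition, read by MTT assay, with a stated time of 72 h; a higher number here means a weaker inhibitor, a lower number a stronger inhibitor.
Compound 2 `COc1cc(-c2nc(SCc3cn(CC(=O)NC(=O)Nc4ccccn4)nn3)nc(Nc3cccc(Cl)c3)c2C#N)cc(OC)c1OC` gives only a limit in this assay, > 64000 nM.
Compound 3 `Cc1ccc(Nc2nc(SCc3cn(CC(=O)NC(=O)Nc4ccccn4)nn3)nc(-c3ccc(C)cc3)c2C#N)cc1` likewise gives only a limit in this assay, > 64000 nM.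

The change from compound 1 to compound 2 is 3-chlorophenyl in place of 4-methylphenyl on a nitrogen on an aromatic ring, and it produced an at least 3.0-fold higher number from compound 1 to compound 2 (0.47 log units; beyond the scatter). Compound 3 differs from compound 1 in its core: 4-methylphenyl in place of 3,4,5-trimethoxyphenyl on an aromatic carbon, a change that produced an at least 3.0-fold higher number from compound 1 to compound 3 (0.47 log units; beyond the scatter). Compound 4 `Cc1ccc(-c2nc(SCc3cn(CC(=O)NC(=O)Nc4ccccn4)nn3)nc(Nc3cccc(Cl)c3)c2C#N)cc1` has not been measured yet. It carries the same change as compound 2, (3-chlorophenyl in place of 4-methylphenyl on a nitrogen on an aromatic ring), placed on the core of compound 3; the surroundings of the place are the same in both cases, a nitrogen on an aromatic ring whose other neighbour is aromatic carbon. Compound 3 already sits at the limit of > 64000 nM in this assay, at which 2 of the 3 values shown sit, and the earlier step of an at least 3.0-fold higher number from compound 1 to compound 2 (0.47 log units; beyond the scatter) pointed toward a weaker inhibitor, so the step from compound 3 to compound 4 is expected to be at least a step that the limit leaves unreadable from compound 3 to compound 4 and most likely to end again at a limit. Compound 4 is therefore estimated at 150000 nM, with a range from 64000 nM to 400000 nM.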

Compound 4, half-maximal inhibitory concentration: 25600 nM
For compound 4 the middle estimate is 5.9-fold (0.77 log units) above the measured one; the measured number lies below the stated range.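

In this assay, putting 3-chlorophenyl in place of 4-methylphenyl on the nitrogen gives an at least 2.5-fold lower number from compound 3 to compound 4 (0.39 log units; beyond the scatter) and so does not act alike on the two cores, since the direction reverses: the same change on two cores in this assay, an at least 3.0-fold higher number (0.47 log units; beyond the scatter) from compound 1 to compound 2 and an at least 2.5-fold lower number (0.39 log units; beyond the scatter) from compound 3 to compound 4, at least 7.5-fold (0.87 log units) apart, beyond the scatter of two such steps.
Putting 4-methylphenyl in place of 3,4,5-trimethoxyphenyl gives an at least 2.5-fold lower number from compound 2 to compound 4 (0.39 log units; beyond the scatter) and likewise reverses its direction between the two partners on the nitrogen: the same change on two cores in this assay, an at least 3.0-fold higher number (0.47 log units; beyond the scatter) from compound 1 to compound 3 and an at least 2.5-fold lower number (0.39 log units; beyond the scatter) from compound 2 to compound 4, at least 7.5-fold (0.87 log units) apart, beyond the scatter of two such steps.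
Both steps start from a limit, so only their smallest possible size is known, and these four compounds show neither the full size of the reversal nor what causes it.

Whether the reversal is particular to these four compounds stays open, as only two groups are shown at each of the two places. An amine or a longer chain at either place, or a carboxylic acid on the aromatic ring that replaces 4-methylphenyl, could test whether the two changes depend on each other more widely.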